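The source may report more compounds than this note shows. Statements on the series, on what has been measured and on what is new or still open speak of the compounds shown alone.

Measured compounds:
Compound 1, `COc1ccc(N/C=C\C(=O)c2nc(-c3ccc(C(F)(F)F)cc3)n3ccccc23)cc1OC`: in a functional assay on A549 cells (Homo sapiens) for cytotoxicity, read by MTT assay, with a stated time of 48 h (on this read-out lower numbers stand for stronger inhibition and higher numbers for weaker inhibition), compound 1 gives > 30000 nM, which is a limit of the assay and not a number.
Compound 2, `COc1ccc(-c2nc(C(=O)/C=C\Nc3ccc(Cl)cc3)c3ccccn23)cc1`: in this assay compound 2 gives "not determined" (no result reported).

For the measured compounds named here, compound 2 therefore stands on no number in this assay; the one further value shown is a limit, (the limit of > 30000 nM in this assay, at which 1 of the 2 values shown sits). Compound 3, `O=C(/C=C\Nc1ccc(Cl)cc1)c1nc(-c2ccc(C(F)(F)F)cc2)n2ccccc12`, differs from compound 2 by trifluoromethyl in place of methoxy on an aromatic carbon. Going by the values given here, no measured step covers this change, so in this assay no step beyond the usual scatter is expected in either direction. Compound 3 is expected to give about 20000 nM in this assay, within a range of 5000 nM to 60000 nM.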

Compound 3, half-maximal inhibitory concentration: 18500 nM
Compound 3: middle estimate off by 1.1-fold (0.03 log units), on the high side; the range from low to high includes it.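

For the compounds shown here, compound 3 gives the first true number in this assay, so a compound with 4-(trifluoromethyl)phenyl can be placed on this scale. Putting 4-chlorophenyl in place of 3,4-dimethoxyphenyl on the amine nitrogen gives an at least 1.6-fold lower number from compound 1 to compound 3 (0.20 log units; that floor lies within the scatter), so no real gain can be claimed. Compound 1 carries a limit of the assay and not a number, and the true size of the step stays unknown because of it: the limit of > 30000 nM in this assay, at which 1 of the 3 values shown sits.

The change from 4-methoxyphenyl to 4-(trifluoromethyl)phenyl cannot be read, as compound 2 has no result. Also open, going by these compounds, is how a nitrile or a carboxylic acid in place of trifluoromethyl would read.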